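Series notes: carrying the trifluoromethyl change onto compound 3

A few compounds are considered here, and "the series" means these few. Any claim that something is new, unique, unknown or untested is made for them only; others in the source may bear on it.

Of the compounds shown here, three have been measured in a functional assay on MCF7 cells (Homo sapiens) for inhibition, read by MTT assay, with a stated time of 72 h; a higher number here means a weaker inhibitor, a lower number a stronger inhibitor. Compound 1 `Cc1ccc(Nc2nc(SCc3cn(CC(=O)NC(=O)Nc4ccccn4)nn3)nc(-c3ccc(C)cc3)c2C#N)cc1` gives 39600 nM. Compound 2 `Cc1ccc(-c2nc(SCc3cn(CC(=O)NC(=O)Nc4ccccn4)nn3)nc(Nc3cccc(C(F)(F)F)c3)c2C#N)cc1` gives 6120 nM in this assay. Compound 3 `Cc1ccc(Nc2nc(SCc3cn(CC(=O)NC(=O)Nc4ccccn4)nn3)nc(-c3ccc(Br)cc3)c2C#N)cc1` gives 14400 nM in this assay.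

Two single-point steps lead away from compound 1. The first is a 6.5-fold lower number from compound 1 to compound 2 (0.81 log units; beyond the scatter), the change being (3-(trifluoromethyl)phenyl in place of 4-methylphenyl on a nitrogen on an aromatic ring). The second is a 2.8-fold lower number from compound 1 to compound 3 (0.44 log units; beyond the scatter), the change being (bromo in place of methyl on an aromatic carbon); this is also the difference between the core of compound 1 and the core of compound 3.

Compound 4 `N#Cc1c(Nc2cccc(C(F)(F)F)c2)nc(SCc2cn(CC(=O)NC(=O)Nc3ccccn3)nn2)nc1-c1ccc(Br)cc1` is not yet measured. It differs from compound 3 by 3-(trifluoromethyl)phenyl in place of 4-methylphenyl on a nitrogen on an aromatic ring. The place of this change is described in the same words as for the pair compound 1 and compound 2, so it is the same change, now made on the bromo-bearing core; this is its second occurrence among the compounds shown.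

For compound 4 a step of a 4.8-fold lower number from compound 3 to compound 4 (0.68 log units; beyond the scatter) is expected, somewhat smaller than the earlier instance, because that instance gave a 6.5-fold lower number from compound 1 to compound 2 (0.81 log units; beyond the scatter) and two separately helpful changes on one core need not add fully. Compound 4 is therefore estimated at 3000 nM in this assay, with a likely range from 1000 nM to 9000 nM. This expectation rests on one prior instance of the change and on compound 3 alone as the starting point.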

Compound 4, half-maximal inhibitory concentration: 3110 nM
Compound 4: the middle estimate sits 1.0-fold (0.02 log units) below what was measured; the measured number falls inside the stated range.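

In this assay, putting 3-(trifluoromethyl)phenyl in place of 4-methylphenyl on the nitrogen carries over to the bromo-bearing core, giving a 4.6-fold lower number from compound 3 to compound 4 (0.67 log units; beyond the scatter), and the two instances of the change do not differ: the same change on two cores in this assay, a 6.5-fold lower number (0.81 log units; beyond the scatter) from compound 1 to compound 2 and a 4.6-fold lower number (0.67 log units; beyond the scatter) from compound 3 to compound 4, 1.4-fold (0.15 log units) apart, within the scatter of two such steps. Bromo in place of methyl, read on the core carrying 3-(trifluoromethyl)phenyl, gives a 2.0-fold lower number from compound 2 to compound 4 (0.29 log units; within the scatter), so on that core the step does not stand out from the scatter, and compound 2 and compound 4 cannot be ranked, although this instance and the earlier one do not differ either: the same change on two cores in this assay, a 2.8-fold lower number (0.44 log units; beyond the scatter) from compound 1 to compound 3 and a 2.0-fold lower number (0.29 log units; within the scatter) from compound 2 to compound 4, 1.4-fold (0.15 log units) apart, within the scatter of two such steps. Among the compounds shown here, this shows that each change behaves alike on the two cores available in this one cell assay, but with only two instances of each change it does not show that the agreement extends to other cores or assays, and it gives no explanation for the size of either step.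

The compounds shown leave open whether a plain phenyl or a methoxyphenyl on the same nitrogen would follow the same course. Going by these compounds, it also remains open whether a chloro group or a carboxylic acid in place of the bromo would keep the two changes as consistent as they are here.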